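The compounds below may be only part of what the source reports. "The series", "measured", "known", "first", "only" and "open" are said of these compounds alone.

Measured compounds:
- compound 1, `CC(CCNC(=O)c1c(Cl)cncc1Cl)N1CCC(C(Oc2ccccn2)c2ccc(C(F)(F)F)cc2)CC1`: 34100 nM
- compound 2, `CC(CCNC(=O)c1c(Cl)cncc1Cl)N1CCC(C(Oc2cccc(Cl)n2)c2ccc(OC(F)(F)F)cc2)CC1`: 6000 nM
- compound 3, `CCO/N=C(/c1ccc(Br)cc1)C1CCN(C2(CCNC(=O)c3c(Cl)cncc3Cl)CC2)CC1`: 33000 nM

All three numbers come from an ADME assay on PBMC cells (Homo sapiens) for cytotoxicity; a lower number here means that less compound is tolerated, a higher number that more compound is tolerated. In this assay compound 1 gives 34100 nM, the highest of the three values, so it is the compound of which the cells tolerate the most. Compound 3 gives 33000 nM, and the gap between compound 1 and compound 3 is within the scatter of this kind of measurement, so no order between the two can be claimed. Compound 2 gives 6000 nM, a clearly lower number, and that gap lies beyond the scatter. No two of these compounds differ in only one place, so none of these gaps can be tied to a single structural change.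

Compound 4, `CC(CCNC(=O)c1c(Cl)cncc1Cl)N1CCC(C(Oc2cccc(Cl)c2)c2ccc(C(F)(F)F)cc2)CC1`, has not yet been measured in this assay. It is compound 1 with one change: 3-chlorophenyl in place of pyridin-2-yl on an oxygen on a saturated carbon. Among the compounds with values here, nothing among the measured compounds isolates this change, so the direction rests on a guess. The step of a 1.7-fold lower number from compound 1 to compound 4 (0.23 log units; within the scatter) is expected to be a modest lowering, possibly within the scatter. Compound 4 is therefore estimated at 20000 nM, with a plausible range from 8000 nM to 45000 nM.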

Compound 4, half-maximal cytotoxic concentration: 8100 nM
For compound 4 the middle estimate is 2.5-fold (0.39 log units) above the measured one; the measured number falls inside the stated range.
By their numbers in this assay, from the lowest: compounds 2 and 4 (each within the scatter of the next); then compounds 3 and 1 (each within the scatter of the next).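

In this assay, within the data shown here, putting 3-chlorophenyl in place of pyridin-2-yl on an oxygen on a saturated carbon gives a 4.2-fold lower number from compound 1 to compound 4 (0.62 log units; beyond the scatter) and so provides the first single change in this set whose effect can be read, showing that the number responds to what sits at this position. The swap alters more than one thing at once: the group that leaves has a nitrogen in its ring and a hydrogen-bond acceptor, while the group that enters has an all-carbon ring, no hydrogen-bond acceptor and a chlorine, so the step alone cannot assign the drop to any one of these differences. No measurement at hand bears on why the number falls.

The compounds shown leave open whether the loss of the ring nitrogen or the arrival of the chlorine matters more, a question that an unsubstituted phenyl on this oxygen would help to separate. Also open, as far as these compounds go, is whether a smaller fluorine or a methoxy group in place of the chlorine would give a number closer to that of compound 1.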